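Swapping the bicyclic amine for a ureido-pyrrolidine

The source may report more compounds than this note shows. Statements on the series, on what has been measured and on what is new or still open speak of the compounds shown alone.

Compound 2 `O=C(CCc1ccc(C(F)(F)F)cc1)Nc1ccc2nc(N3CC4CCC3C4)ccc2c1` sits at the low end of the three numbers in hand: in an assay on isolated protein for displacement of a labelled ligand from melanin-concentrating hormone receptor 1 (Homo sapiens) (on this read-out higher numbers stand for weaker inhibition and lower numbers for stronger inhibition), compound 2 gives 1 nM. Compound 1 `CC(C)N(C)c1ccc2cc(NC(=O)CCc3ccc(C(F)(F)F)cc3)ccc2n1` is the nearest neighbour: in this assay compound 1 gives 2 nM. Compound 3 `O=C(CCCCCCCCCCCCc1ccc(C(F)(F)F)cc1)Nc1ccc2nc([N+]34CCC(CC3)CC4)ccc2c1` is the furthest: in this assay compound 3 gives 5 nM. Compound 4 `CNC(=O)NC1CCN(c2ccc3cc(NC(=O)CCc4ccc(C(F)(F)F)cc4)ccc3n2)C1` carries a group of 10 heavy atoms (6 carbon, 3 nitrogen, 1 oxygen; one five-membered non-aromatic ring with 1 hetero atom) in place of a group of 7 heavy atoms (6 carbon, 1 nitrogen; one five-membered non-aromatic ring of carbon only, one five-membered non-aromatic ring with 1 hetero atom), on an aromatic carbon. For the measured compounds named here, the only single-point step at this same position, a 2.0-fold lower number from compound 1 to compound 2 (0.30 log units; within the scatter), shows that replacing one amine substituent by another left the number essentially unchanged. Going by the values given here, no measured pair covers the entry of a urea-bearing group, so compound 4 is expected to move little: the estimated step is a 3.0-fold higher number from compound 2 to compound 4 (0.48 log units; beyond the scatter). Compound 4 is therefore expected to give about 3 nM in this assay, plausibly between 1 nM and 12 nM.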

Compound 4, half-maximal inhibitory concentration: 6 nM
The estimate for compound 4 lay 2.0-fold (0.30 log units) below the measured number; the range from low to high includes it.
By their numbers in this assay, from the lowest: compounds 2 and 1 (each within the scatter of the next); then compounds 3 and 4 (each within the scatter of the next).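

Unlike the step from compound 1 to compound 2, which stayed within the scatter, the entry of the 3-((methylcarbamoyl)amino)pyrrolidin-1-yl group moves the number beyond it: a 6.0-fold higher number from compound 2 to compound 4 (0.78 log units; beyond the scatter), and a 3.0-fold higher number from compound 1 to compound 4 (0.48 log units; beyond the scatter). Both steps are modest, so this position accepts the urea-bearing group at a small cost, with compound 4 still at 6 nM. No evidence on hand speaks to what lies behind this shift. Going by these compounds, it remains open whether an unsubstituted pyrrolidin-1-yl or a 3-aminopyrrolidin-1-yl would give a number closer to that of compound 2 or to that of compound 4, and so whether the urea or the ring carries the step.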